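Shortening the Sulfonyl Substituent at the Chain End

This account rests on a few compounds, and the source may have more. Where it says the series, first, only, none or still open, it means among the compounds named here.

Going by the values given here, compound 2 `COc1ccccc1Oc1c(NS(=O)(=O)c2ccc(C(C)C)cn2)nc(C2CC2)nc1OCCCNS(=O)(=O)c1cccs1` gives 120 nM in a functional assay for inhibition of Endothelin-1 receptor (Rattus norvegicus) (a lower number here means tighter binding, a higher number weaker binding), the lowest of the two numbers so far; the nearest is compound 1 `CCCS(=O)(=O)NCCCOc1nc(C2CC2)nc(NS(=O)(=O)c2ccc(C(C)C)cn2)c1Oc1ccccc1OC`, which gives 245 nM. Among the compounds with values here, the only step in hand, a 2.0-fold lower number from compound 1 to compound 2 (0.31 log units; beyond the scatter), replaced propyl with thiophen-2-yl on a sulfonyl sulfur. Compound 3 `CCS(=O)(=O)NCCCOc1nc(C2CC2)nc(NS(=O)(=O)c2ccc(C(C)C)cn2)c1Oc1ccccc1OC` differs from compound 2 by ethyl in place of thiophen-2-yl on a sulfonyl sulfur. This runs the measured change the other way onto a shorter chain, so a modest rise is expected, a 2.3-fold higher number from compound 2 to compound 3 (0.37 log units; beyond the scatter), because the step of a 2.0-fold lower number from compound 1 to compound 2 (0.31 log units; beyond the scatter) pointed downward. Compound 3 is therefore estimated at 280 nM, within 140 nM to 560 nM.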

Compound 3, dissociation constant: 105 nM
Compound 3: the middle estimate sits 2.7-fold (0.43 log units) above what was measured; the whole stated range lies above it.
By their numbers in this assay, from the lowest: compounds 3 and 2 (each within the scatter of the next); then compound 1.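

With a 1.1-fold lower number from compound 2 to compound 3 (0.06 log units; within the scatter) in this assay the ethyl and thiophen-2-yl groups cannot be told apart, so on this sulfonyl sulfur the five-membered aromatic ring is not needed to keep the number seen with compound 2. With a 2.3-fold lower number from compound 1 to compound 3 (0.37 log units; beyond the scatter) the change of methyl to hydrogen on a saturated chain carbon, two bonds along the chain from a sulfonyl sulfur, goes beyond the scatter, and the propyl group of compound 1 stands apart. No evidence in hand accounts for either step.

Still open, as far as these compounds go, is whether methyl on this sulfur, or a chain ending in an amine or a carboxylic acid, would keep the number, and whether phenyl would match thiophen-2-yl.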